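Replacing 1H-imidazol-1-yl in compound 3

This account rests on a few compounds, and the source may have more. Where it says the series, first, only, none or still open, it means among the compounds named here.

In a functional assay (trachea) with Cavia porcellus as the target (a lower number here means a stronger inhibitor, a higher number a weaker inhibitor), compound 1 `O=c1c2ccccc2c(-c2cccnc2)nn1Cc1ccccc1` gives 2450 nM and compound 2 `O=C(O)c1ccc(Cn2nc(-c3cccnc3)c3ccccc3c2=O)cc1` gives 17000 nM. Compound 3 `Oc1nnc(-n2ccnc2)c2ccccc12` gives 8320 nM, the second highest of the three numbers, which places it nearer to compound 2 than to compound 1.

Compound 4 `Oc1nnc(-c2cncs2)c2ccccc12` differs from compound 3 in one place, where 1,3-thiazol-5-yl stands in place of 1H-imidazol-1-yl on an aromatic carbon, para to a hydroxy group: 1,3-thiazol-5-yl in place of 1H-imidazol-1-yl on an aromatic carbon. Each group is one five-membered aromatic ring with 2 hetero atoms and no net charge.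

For the measured compounds named here, only one measured step is available, a 6.9-fold higher number from compound 1 to compound 2 (0.84 log units; beyond the scatter), and it is a modest step beyond the scatter. It concerns carboxy in place of hydrogen, a different change on a different core, so it bears only indirectly. It shows that one change can move the number in this small set, but it gives no direction for the present exchange. Going by the values given here, no measured pair makes this exchange of groups.

In this assay, no step beyond the scatter is therefore expected, and the expected step is a 1.3-fold lower number from compound 3 to compound 4 (0.11 log units; within the scatter). The estimate for compound 4 is 6500 nM, with an expected range from 1800 nM to 22000 nM.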

Compound 4, half-maximal inhibitory concentration: 1200 nM
Compound 4: the middle estimate sits 5.4-fold (0.73 log units) above what was measured; the whole stated range lies above it.
By their numbers in this assay, from the lowest: compound 4; then compound 1; then compound 3; then compound 2.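

In this assay, this position on the shared core, para to a hydroxy group, responds clearly to the choice of five-membered aromatic ring: the exchange gives a 6.9-fold lower number from compound 3 to compound 4 (0.84 log units; beyond the scatter). The leaving and entering groups have the same counts of heavy atoms, hydrogen-bond donors and hydrogen-bond acceptors, and neither carries a net charge, so matching these counts does not fix the number here; the earlier step, which concerned carboxy in place of hydrogen on a different core, could not show this. Nothing measured here explains why the thiazolyl group gives the lower number, so the step stands as an observation without a stated cause.

The two groups differ both in holding sulfur in place of one nitrogen and in being attached through a ring carbon rather than a ring nitrogen, and this single pair cannot separate those two differences. Going by these compounds, it remains open how a 1,3-oxazol-5-yl or a phenyl group would behave at this position, and whether an amine in place of the hydroxy group would preserve the number of compound 4.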